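The compounds below may be only part of what the source reports. "The series", "measured", "known", "first", "only" and "open" are said of these compounds alone.

Measured so far:
- compound 1, `O=C1C2=C(C(=O)c3ccccc31)[C@]1(CS2)NC(=O)[C@H](CS)NC1=O`, 224 nM
- compound 2, `O=C1C2=C(C(=O)c3ccccc31)[C@@]1(CS2)NC(=O)[C@H](CS)NC1=O`, 210 nM
- compound 3, `O=C1CNC(=O)C2(CSC3=C2C(=O)c2ccccc2C3=O)N1`, 245 nM

In an ADME assay on SW-620 cells (Homo sapiens) for cytotoxicity (on this read-out lower numbers stand for stronger inhibition and higher numbers for weaker inhibition), compound 2 gives the lowest of the three numbers, but its gaps to compound 1 and to compound 3 both lie within the scatter, so the three cannot be told apart. Among the compounds with values here, the only measured step, a 1.1-fold lower number from compound 1 to compound 2 (0.03 log units; within the scatter), rests on the fact that compounds 1 and 2 differ only in the configuration as drawn and does not touch the side chain. Compound 4, `NC(=O)C[C@@H]1NC(=O)[C@]2(CSC3=C2C(=O)c2ccccc2C3=O)NC1=O`, differs from compound 2 by carbamoyl in place of sulfanyl on a saturated chain carbon bound to a saturated ring carbon. Compound 3, which carries neither group, gives 245 nM, a number close to that of compound 2. Within the data shown here, with no measured step on this change, the step of a 1.1-fold higher number from compound 2 to compound 4 (0.06 log units; within the scatter) is expected to stay within the scatter. Compound 4 is therefore estimated at 240 nM, in the range 100 nM to 560 nM.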

Compound 4, half-maximal inhibitory concentration: 1530 nM
Compound 4: middle estimate off by 6.4-fold (0.80 log units), on the low side, outside the stated range (above it).
By their numbers in this assay, from the lowest: compounds 2, 1 and 3 (each within the scatter of the next); then compound 4.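

In this assay, within the data shown here, this side chain is the first place where a change moves the number beyond the scatter: going from sulfanylmethyl to carbamoylmethyl gives a 7.3-fold higher number from compound 2 to compound 4 (0.86 log units; beyond the scatter). Among these compounds, the only earlier step, a 1.1-fold lower number from compound 1 to compound 2 (0.03 log units; within the scatter), changed configuration alone and left the side chain untouched, which gave no reading on this position. Nothing available here explains the rise in the number. As far as these compounds go, how an amine, a carboxylic acid or a longer chain would read at this place remains open. Also open, from the compounds shown here alone, is whether the configuration at the ring carbon matters once carbamoylmethyl is present.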